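From a triazolyl to a pyridinylethyl side group

A few compounds are considered here, and "the series" means these few. Any claim that something is new, unique, unknown or untested is made for them only; others in the source may bear on it.

Going by the values given here, compound 2 `Cn1cc([C@@H](O)[C@H]2C(=O)N3C(C(=O)O)=C(C(C)(C)C)O[C@H]23)nn1` gives 6.8 h in an ADME assay, in phosphate buffer, at 28 degrees C, at pH 7.0; on this read-out higher numbers stand for a longer-lived compound and lower numbers for a shorter-lived compound; of the two numbers so far, the other comes from compound 1 `COC(=O)[C@@H](O)[C@H]1C(=O)N2C(C(=O)O)=C(C(C)(C)C)O[C@H]12`, which gives 6.2 h and lies within the scatter of compound 2. Compound 3 `CC(C)(C)C1=C(C(=O)O)N2C(=O)[C@H]([C@H](O)CCc3ccncc3)[C@H]2O1` differs from compound 2 by 2-(pyridin-4-yl)ethyl in place of 1-methyl-1H-1,2,3-triazol-4-yl on a saturated chain carbon bound to an oxygen on a saturated carbon and a saturated ring carbon. Among the compounds with values here, the only measured step at this place, a 1.1-fold higher number from compound 1 to compound 2 (0.04 log units; within the scatter), stayed within the scatter, so for compound 3 no step beyond the scatter is expected in this assay. The expected step is a 1.0-fold lower number from compound 2 to compound 3 (0.02 log units; within the scatter). Compound 3 is therefore estimated at 6.5 h, with a range from 3.5 h to 12 h.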

Compound 3, half-life: 13.7 h
Beside the measured number, compound 3's estimate is 2.1-fold (0.32 log units) below it; measured number above the stated range.
By their numbers in this assay, from the lowest: compounds 1, 2 and 3 (each within the scatter of the next, the first and the last beyond it).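

With 2-(pyridin-4-yl)ethyl in place of methoxycarbonyl, this position in this assay shows a 2.2-fold higher number from compound 1 to compound 3 (0.34 log units; beyond the scatter) as its first step beyond the scatter. Set against 1-methyl-1H-1,2,3-triazol-4-yl, the same group gives a 2.0-fold higher number from compound 2 to compound 3 (0.30 log units; within the scatter) so only the comparison with methoxycarbonyl clears the scatter. Nothing available here accounts for the step. The compounds shown leave open whether the two-carbon link or the pyridine ring goes with the longer half-life. A 2-phenylethyl group, a directly attached pyridin-4-yl or a longer chain ending in the same ring would separate these.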